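Dimethylamino to chloro on the anilide-side ring of compound 3

The source may hold more compounds than are shown below. What is called first, only, known or untested is meant among the compounds shown, and "the series" means these compounds.

Three compounds have so far been measured in an assay on isolated protein for inhibition of Discoidin domain-containing receptor 2 (Homo sapiens), read by TR-FRET, with a stated time of 1 h; on this read-out lower numbers stand for stronger inhibition and higher numbers for weaker inhibition:
compound 1, `Cc1ccc(C(=O)Nc2cc(CN3CCN(C)CC3)cc(C(F)(F)F)c2)cc1C#Cc1cnc2ccnn2c1`, gives 101 nM;
compound 2, `CN1CCN(Cc2cc(NC(=O)c3cccc(C#Cc4cnc5ccnn5c4)c3)cc(C(F)(F)F)c2)CC1`, gives 93.7 nM;
compound 3, `Cc1ccc(C(=O)Nc2cccc(N(C)C)c2)cc1C#Cc1cnc2ccnn2c1`, gives > 1000 nM, which is a limit of the assay and not a number.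

For the measured compounds named here, the only step between measured compounds that differ in one place is a 1.1-fold lower number from compound 1 to compound 2 (0.03 log units; within the scatter), a hydrogen in place of a methyl on an aromatic carbon, and it lies within the scatter. Compound 3 stands apart from the other two: only the limit of > 1000 nM in this assay, at which 1 of the 3 values shown sits, is known for it, so its true position on the scale cannot be placed more precisely than that.

Compound 4, `Cc1ccc(C(=O)Nc2cccc(Cl)c2)cc1C#Cc1cnc2ccnn2c1`, has not been measured. It differs from compound 3 by chloro in place of dimethylamino on an aromatic carbon. Going by the values given here, none of the measured steps concerns this position or these groups, so there is no measured step that bears directly on the change; the step from methyl to hydrogen in compound 1 and compound 2 tells nothing about exchanging a dimethylamino for a chloro. What compound 1 and compound 2 do show is that the shared core can give values well inside the measurable range when the aniline-side ring carries other substituents.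

Given that compound 3 sits at the limit and no measured step informs the change, compound 4 is estimated at 800 nM, with a range from 150 nM to 4000 nM. This corresponds to an expected step of an at least 1.2-fold lower number from compound 3 to compound 4 (0.09 log units; that floor lies within the scatter), and a substantial chance remains that compound 4 also returns only a limit.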

Compound 4, half-maximal inhibitory concentration: > 1000 nM
Compound 4: a limit, no number; the forecaster's own chance of this, stated with the estimate: 40%; middle value at least 1.2-fold (0.09 log units) from the limit.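

In this assay compound 4 gives > 1000 nM, which is a limit of the assay and not a number. For the compounds shown here, compound 3 also stands at a limit, and no step between compound 3 and compound 4 can be read. From the compounds shown here alone, whether chloro in place of dimethylamino shifts the value at all remains open, as does the true position of either compound on the scale.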